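Cytotoxicity of a shared core ahead of the nitro analogue

The compounds below may be only part of what the source reports. "The series", "measured", "known", "first", "only" and "open" are said of these compounds alone.

Measured in an ADME assay on BHK cells (Mesocricetus auratus) for cytotoxicity, read by MTT assay, with a stated time of 96 h; on this read-out higher numbers stand for lower toxicity in this test and lower numbers for higher toxicity in this test:
compound 1 `COc1ccc(-c2nc3cc(Cl)c(Cl)cc3[nH]2)cc1` gives 18000 nM
compound 2 `Nc1ccc(-c2nc3cc(Cl)c(Cl)cc3[nH]2)cc1` gives 30000 nM
compound 3 `O=C(CN1CCCCC1)Nc1ccc(-c2nc3cc(Cl)c(Cl)cc3[nH]2)cc1` gives 39000 nM

All three compounds share one core and differ only in the group on the outer six-membered ring. Compound 2 sits between the other two numbers, and both gaps are small: a 1.7-fold higher number from compound 1 to compound 2 (0.22 log units; within the scatter), and a 1.3-fold higher number from compound 2 to compound 3 (0.11 log units; within the scatter). Neither step rises above the scatter, so the three compounds cannot be told apart in this assay on these numbers.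

Compound 4 `O=[N+]([O-])c1ccc(-c2nc3cc(Cl)c(Cl)cc3[nH]2)cc1` is the next member of the set, differing from compound 2 at one place: nitro in place of amino on an aromatic carbon.

The two measured steps both touch the same position of the outer ring, the first exchanging the group there, the second building on its nitrogen, and both stayed within the scatter. On that record the exchange in compound 4 is expected to give no step beyond the scatter either, in either direction. Compound 4 is therefore estimated at 25000 nM, with a range from 10000 nM to 60000 nM. The expected step is a 1.2-fold lower number from compound 2 to compound 4 (0.08 log units; within the scatter).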

Compound 4, half-maximal cytotoxic concentration: > 100000 nM
Compound 4: no number, only a limit; the forecaster's own chance of this, stated with the estimate: 10%; at least 4.0-fold (0.60 log units) between middle value and limit.
By their numbers in this assay, from the lowest: compounds 1, 2 and 3 (each within the scatter of the next, the first and the last beyond it). At a limit, above all of these: compound 4.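

In this assay, the group on this aromatic carbon turns out to matter: the two earlier steps stayed within the scatter, whereas nitro in place of amino gives an at least 3.3-fold higher number from compound 2 to compound 4 (0.52 log units; beyond the scatter), and nitro in place of methoxy gives an at least 5.5-fold higher number from compound 1 to compound 4 (0.74 log units; beyond the scatter). Both new steps point towards lower toxicity in this test, and nitro is the only group shown here that produces a step beyond the scatter at this position. Compound 4 carries a limit rather than a number, so the full size of both steps remains unknown: the limit of > 100000 nM in this assay, at which 1 of the 4 values shown sits.

The compounds shown leave open whether this step is particular to nitro, or whether a nitrile or a carboxylic acid on the same carbon would also give a step beyond the scatter. They also leave open how far beyond its limit the true value of compound 4 lies.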